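Methoxy to Methyl on a Cell-Tolerated Scaffold

A few compounds are considered here, and "the series" means these few. Any claim that something is new, unique, unknown or untested is made for them only; others in the source may bear on it.

Of the compounds shown here, three have been tested so far in a functional assay on U-251 cells (Homo sapiens) for inhibition, read by MTT assay, with a stated time of 2 days; a higher number here means that more compound is tolerated, a lower number that less compound is tolerated. Compound 1 `Nc1ccccc1NC(=O)CCCNCC(=O)Nc1cc(Cl)ccc1Cl` gives a reading of > 100000 nM, which is a limit of the assay rather than a number. Compound 3 `Nc1ccccc1NC(=O)CCCNCC(=O)Nc1ccc(Br)cc1` likewise gives > 100000 nM, again a limit. The step that the two limits leave unreadable from compound 1 to compound 3 therefore cannot be sized, since both ends sit at the limit of > 100000 nM in this assay, at which 3 of the 3 values shown sit. Compound 2 `COc1ccc(NC(=O)CNc2ccc(C(=O)Nc3ccccc3N)cc2)cc1` also gives > 100000 nM in this assay, once more a limit, so compound 2 stands at the same edge as every other compound measured here.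

The next compound, compound 4 `Cc1ccc(NC(=O)CNc2ccc(C(=O)Nc3ccccc3N)cc2)cc1`, differs from compound 2 in one place: methyl in place of methoxy on an aromatic carbon. Among the measured compounds shown here, no measured step involves this change, and the one measured step between related compounds is unreadable, so there is no evidence for a shift in either direction. For the measured compounds named here, every measured compound lies at the limit, which suggests compound 4 will do the same, though only three compounds support that view.

Compound 4 is therefore expected to be tolerated to the same extent, with the step of a number no higher from compound 2 to compound 4 (the limit leaves the size open) expected to be negligible. The estimate for compound 4 is 100000 nM, in the range from 50000 nM to 200000 nM, most likely reported again as a limit.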

Compound 4, concentration lethal to 50% of the cells: > 100000 nM
Compound 4: no number, only a limit (the forecaster's own chance of this, stated with the estimate: 85%); the middle value lies on the limit itself.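

Among the compounds shown here, compound 2 and compound 4 both end at a limit rather than a number, so the change from methoxy to methyl gives no step that can be read in this assay. All the compounds shown share that same edge: the limit of > 100000 nM in this assay, at which 4 of the 4 values shown sit. They leave open what the lethal concentration is, and whether any of these structural changes shifts it.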